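From 4-nitrobenzyl to octyl on an aromatic nitrogen

The compounds below may be only part of what the source reports. "The series", "measured", "known", "first", "only" and "open" are said of these compounds alone.

Three compounds share one core and differ only in the group on an aromatic nitrogen, and all three have been measured in a functional assay on A549 cells (Homo sapiens) for antiproliferative activity, read by MTT assay; on this read-out higher numbers stand for weaker inhibition and lower numbers for stronger inhibition. Compound 1 `CC1(C)CCc2cc(C(=O)/C=C/c3ccc(OCc4cn(-c5ccc(Cl)cc5)nn4)cc3)c(O)cc2O1` gives 75500 nM, and compound 2 `CCc1ccccc1-n1cc(COc2ccc(/C=C/C(=O)c3cc4c(cc3O)OC(C)(C)CC4)cc2)nn1` gives 137000 nM. The change between them is a 1.8-fold higher number from compound 1 to compound 2 (0.26 log units; within the scatter). Compound 3 `CC1(C)CCc2cc(C(=O)/C=C/c3ccc(OCc4cn(Cc5ccc([N+](=O)[O-])cc5)nn4)cc3)c(O)cc2O1`, at 35800 nM, holds the lowest number of the three. The measured steps that reach it are a 2.1-fold lower number from compound 1 to compound 3 (0.32 log units; beyond the scatter) and a 3.8-fold lower number from compound 2 to compound 3 (0.58 log units; beyond the scatter).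

Compound 4 `CCCCCCCCn1cc(COc2ccc(/C=C/C(=O)c3cc4c(cc3O)OC(C)(C)CC4)cc2)nn1` has not yet been measured. Its difference from compound 3 is heptyl in place of 4-nitrophenyl on a saturated chain carbon bound to an aromatic nitrogen, which, cut one bond further out, reads 4-nitrobenzyl to octyl. Among the compounds with values here, no measured compound carries a plain chain on that nitrogen, so the steps bear on this change only indirectly. Both measured replacements of 4-nitrobenzyl go with a higher number, as the two steps into compound 3 show when read backwards, so a small rise is expected rather than a drop. The expected step is a 1.5-fold higher number from compound 3 to compound 4 (0.19 log units; within the scatter). Compound 4 is estimated at 55000 nM, with an expected range of 22000 nM to 130000 nM in this assay.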

Compound 4, half-maximal inhibitory concentration: 50800 nM
Compound 4: the middle estimate sits 1.1-fold (0.03 log units) above what was measured, and the stated range covers the measured number.
By their numbers in this assay, from the lowest: compounds 3, 4, 1 and 2 (each within the scatter of the next, the first and the last beyond it).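

In this assay, the step of a 1.4-fold higher number from compound 3 to compound 4 (0.15 log units; within the scatter) comes with heptyl, a group with no ring and built of carbon only, replacing 4-nitrophenyl on a saturated chain carbon bound to an aromatic nitrogen, so this position accepts a plain chain without separating it from 4-nitrobenzyl. Against the groups that sit directly on the aromatic nitrogen, the result is split: a 1.5-fold lower number from compound 1 to compound 4 (0.17 log units; within the scatter) leaves octyl unseparated from 4-chlorophenyl, whereas a 2.7-fold lower number from compound 2 to compound 4 (0.43 log units; beyond the scatter) sets octyl apart from 2-ethylphenyl. An aromatic ring in this group is therefore not required for a number at the level of compound 4, and compound 2 shows that carrying such a ring does not secure that level.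

Nothing measured here gives a reason for these results. The compounds shown leave open whether a shorter chain or a longer chain would hold the number at this level, and whether an octyl chain ending in an amine or a carboxylic acid would do the same.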